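A few compounds are considered here, and "the series" means these few. Any claim that something is new, unique, unknown or untested is made for them only; others in the source may bear on it.

Measured in a functional assay on MCF7 cells (Homo sapiens) for antiproliferative activity, read by colorimetric assay and sulforhodamine B assay, with a stated time of 3 days; a higher number here means a weaker inhibitor, a lower number a stronger inhibitor:
- compound 1 `Clc1ncnc2c1ncn2CC1COc2ccccc2S1`: 10600 nM
- compound 2 `Clc1ncnc2c1ncn2CC1CSc2ccccc2O1`: 9240 nM
- compound 3 `Brc1ncnc2c1ncn2CC1CSc2ccccc2O1`: 4870 nM

Compound 2 lies within the scatter of both compound 1 and compound 3. Compound 4 `Clc1nc(Cl)c2ncn(CC3CSc4ccccc4O3)c2n1` carries one change from compound 2: chloro in place of hydrogen on an aromatic carbon, between two ring nitrogen atoms. For the measured compounds named here, no measured step adds a group at this carbon. The nearest guide is a halogen exchange at a different carbon, a 1.9-fold lower number from compound 2 to compound 3 (0.28 log units; within the scatter), and it gives only weak support. A small move in this assay towards a lower number is expected, and it may not clear the scatter. The estimated change is a 1.7-fold lower number from compound 2 to compound 4 (0.23 log units; within the scatter). For compound 4 the estimated value is 5500 nM, with an expected range of 2000 nM to 13000 nM.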

Compound 4, half-maximal inhibitory concentration: 2750 nM
Compound 4: middle estimate off by 2.0-fold (0.30 log units), on the high side, within the range that was stated.
By their numbers in this assay, from the lowest: compounds 4, 3, 2 and 1 (each within the scatter of the next, the first and the last beyond it).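

Chloro in place of hydrogen on an aromatic carbon, between two ring nitrogen atoms, gives a 3.4-fold lower number from compound 2 to compound 4 (0.53 log units; beyond the scatter) in this assay and so moves the number beyond the scatter, which the halogen exchange at a different carbon, a 1.9-fold lower number from compound 2 to compound 3 (0.28 log units; within the scatter), did not do. This carbon therefore tolerates a substituent, and adding one lowers the number. Nothing measured here accounts for the step.

On these data alone, whether an amine, a methoxy group or bromo at this carbon would do the same remains open. So does whether chloro there would lower the number on the core of compound 1.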